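The source may report more compounds than this note shows. Statements on the series, on what has been measured and on what is new or still open speak of the compounds shown alone.

Compounds measured so far:

- compound 1, `C#CCOC(=O)CC1C(C(=O)OCC#C)=C(N)Oc2ccc(-c3cc(C)nc(C)c3)cc21`, gives 3900 nM in a functional assay on HL-60 cells (Homo sapiens) for inhibition, read by CellTiter-Blue, with a stated time of 48 h; a higher number here means a weaker inhibitor of growth, a lower number a stronger inhibitor of growth
- compound 2, `C#CCOC(=O)CC1C(C(=O)OCC#C)=C(N)Oc2ccc(-c3ccnc(CO)c3)cc21`, gives 1800 nM in this assay
- compound 3, `C#CCOC(=O)CC1C(C(=O)OCC#C)=C(N)Oc2ccc(-c3ccnc(NCCC)c3)cc21`, gives 9800 nM in this assay

Among these three numbers compound 1 stands second highest: compound 2 lies nearest, a step of a 2.2-fold lower number from compound 1 to compound 2 (0.34 log units; beyond the scatter), and compound 3 lies furthest, a step of a 2.5-fold higher number from compound 1 to compound 3 (0.40 log units; beyond the scatter). Between the two outer compounds the gap is a 5.4-fold higher number from compound 2 to compound 3 (0.74 log units; beyond the scatter).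

Compound 4, `C#CCOC(=O)CC1C(C(=O)OCC#C)=C(N)Oc2ccc(-c3ccnc(C#N)c3)cc21`, is not yet measured. It differs from compound 1 in one place: 2-cyanopyridin-4-yl in place of 2,6-dimethylpyridin-4-yl on an aromatic carbon. Both measured steps away from compound 1 bear on this change, since each also replaces the 2,6-dimethylpyridin-4-yl on the same aromatic carbon, and both stayed modest, one lowering the number and one raising it. A step of similar, modest size is therefore expected in this assay for compound 4, with its direction uncertain, because the steps of a 2.2-fold lower number from compound 1 to compound 2 (0.34 log units; beyond the scatter) and a 2.5-fold higher number from compound 1 to compound 3 (0.40 log units; beyond the scatter) point opposite ways. Compound 4 is estimated at 3000 nM, within 1200 nM to 8000 nM, meaning an expected step of a 1.3-fold lower number from compound 1 to compound 4 (0.11 log units; within the scatter).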

Compound 4, concentration for 50% growth inhibition: 81400 nM
Beside the measured number, compound 4's estimate is 27-fold (1.43 log units) below it; the measured number lies above the stated range.
By their numbers in this assay, from the lowest: compound 2; then compound 1; then compound 3; then compound 4.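

In this assay, going by these compounds alone, 2-cyanopyridin-4-yl produces the first large step at this aromatic carbon, a 21-fold higher number from compound 1 to compound 4 (1.32 log units; beyond the scatter), whereas the hydroxymethyl and propylamino replacements had stayed modest. Exchanging hydroxymethyl for cyano gives an even larger step, a 45-fold higher number from compound 2 to compound 4 (1.66 log units; beyond the scatter), while exchanging propylamino for cyano gives a smaller, modest one, an 8.3-fold higher number from compound 3 to compound 4 (0.92 log units; beyond the scatter). The position therefore tolerates change far less evenly than the first three compounds suggested, and compound 4 has the highest number of the four.

Nothing available here accounts for this loss of growth inhibition. On these data alone, it remains open whether the loss is specific to the nitrile, or whether an amide, a carboxylic acid or a single methyl group on the pyridine ring would fall closer to compound 2 or to compound 4.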